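A few compounds are considered here, and "the series" means these few. Any claim that something is new, unique, unknown or untested is made for them only; others in the source may bear on it.

Values so far in a physicochemical assay for lipophilicity, using the shake flask method, measured as octanol-water partition, at pH 7.4; on this read-out lower numbers stand for lower lipophilicity and higher numbers for higher lipophilicity:

- compound 1 `CC(=O)N[C@@H]1CCC[C@H](C(=O)Nc2cc(-c3cnn4ccccc34)c(Cl)cn2)C1` gives 3.6
- compound 2 `CC(=O)N[C@@H]1CCC[C@H](C(=O)Nc2cc(-c3cnc4ccccn34)c(Cl)cn2)C1` gives 3
- compound 3 `CC(=O)N[C@@H]1CCC[C@H](C(=O)Nc2cc(-c3cnn4c3COCC4)c(Cl)cn2)C1` gives 2.4

Compound 3 stands lowest of the three numbers, with compound 2 the nearest and compound 1 the furthest. The next compound is compound 4 `CC(=O)N[C@@H]1CCC[C@H](C(=O)Nc2cc(-c3cnc4n3CC(C)(C)C4)c(Cl)cn2)C1`, and the change is a group of 10 heavy atoms (8 carbon, 2 nitrogen; one five-membered non-aromatic ring with 1 hetero atom, one five-membered aromatic ring with 2 hetero atoms) in place of a group of 9 heavy atoms (6 carbon, 2 nitrogen, 1 oxygen; one five-membered aromatic ring with 2 hetero atoms, one six-membered non-aromatic ring with 2 hetero atoms), on an aromatic carbon, opposite the ring nitrogen.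

Two measured steps at this same place bear on it: a number 1.20 log units lower from compound 1 to compound 3 (beyond the scatter), which is large, and a number 0.60 log units lower from compound 2 to compound 3 (beyond the scatter), which is modest. In both, the group arriving in compound 3 is the one that contains oxygen. The group in compound 4 has no oxygen, as in compound 1 and compound 2, but it also lacks their six-membered aromatic ring. Only part of those steps is therefore expected to come back, and the direction is expected to be upward. The expected step is a number 0.40 log units higher from compound 3 to compound 4 (beyond the scatter) in this assay, a modest rise. For compound 4 the estimated value is 2.8, with an expected range from 2.3 to 3.3.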

Compound 4, distribution coefficient: 3.6
Compound 4: middle estimate off by 0.80 log units, on the low side; measured number outside the range, above it.
By their numbers in this assay, from the lowest: compound 3; then compound 2; then compounds 1 and 4 (each within the scatter of the next).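

In this assay, the oxygen-free group in compound 4 gives no change at the digits printed from compound 1 to compound 4 (within the scatter), so at this position, opposite the ring nitrogen, a six-membered aromatic ring is not required to reach the level of compound 1. The same entering group gives a number 1.20 log units higher from compound 3 to compound 4 (beyond the scatter) and also a number 0.60 log units higher from compound 2 to compound 4 (beyond the scatter), so a change between groups of near-equal heavy-atom count spans the whole range seen so far in this series. No measurement available here accounts for these steps.

Still open, as far as these compounds go, is how much of the rise belongs to the two methyl groups on the five-membered non-aromatic ring and how much to the ring itself. Also open, from the compounds shown here alone, is whether an amine or a carboxylic acid on that ring would take the number lower than in compound 3.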